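Sulfonyl aryl exchange on the shared core: clearance notes

A few compounds are considered here, and "the series" means these few. Any claim that something is new, unique, unknown or untested is made for them only; others in the source may bear on it.

Compound 2 `N#Cc1cccc(S(=O)(=O)c2cnc3c(F)cccc3c2-c2cccc(Cl)c2)c1` carries a 3-cyanophenyl on the sulfonyl sulfur and gives 1.11 mL/min in an ADME assay on microsomes from liver (Homo sapiens) for metabolic stability, tested at 2.5 uM; a higher number here means faster removal of the compound, a lower number slower removal. Among the compounds with values here, this is the highest of the three numbers so far: compound 3 `N#Cc1cccc(S(=O)(=O)c2cnc3c(F)cccc3c2-c2cccc(F)c2)c1` gives 0.34 mL/min and compound 1 `O=S(=O)(c1ccc(F)c(Cl)c1)c1cnc2c(F)cccc2c1-c1cccc(Cl)c1` gives 0.18 mL/min. The step of a 6.2-fold higher number from compound 1 to compound 2 (0.79 log units; beyond the scatter) and the step of a 3.3-fold lower number from compound 2 to compound 3 (0.51 log units; beyond the scatter) both lie beyond the scatter.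

Compound 4 `O=S(=O)(c1ccc(F)c(F)c1)c1cnc2c(F)cccc2c1-c1cccc(Cl)c1` differs from compound 2 at the sulfonyl aryl: 3,4-difluorophenyl in place of 3-cyanophenyl on a sulfonyl sulfur. The step that bears on this is a 6.2-fold higher number from compound 1 to compound 2 (0.79 log units; beyond the scatter), the reverse exchange on the same position, where a halogenated phenyl in place of the 3-cyanophenyl gave the lower number. The step of a 3.3-fold lower number from compound 2 to compound 3 (0.51 log units; beyond the scatter) concerns the other aryl and does not apply directly. Compound 4 is therefore expected to move back toward compound 1, and its number is estimated as a 4.4-fold lower number from compound 2 to compound 4 (0.65 log units; beyond the scatter), a step beyond the scatter. For compound 4 the expected value in this assay is 0.25 mL/min, with a range from 0.1 mL/min to 0.6 mL/min.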

Compound 4, intrinsic clearance in a liver preparation (reported as CLH), per the amount of preparation that the assay uses: 1.13 mL/min
For compound 4 the middle estimate is 4.5-fold (0.66 log units) below the measured one; measured number outside the range, above it.
By their numbers in this assay, from the lowest: compounds 1 and 3 (each within the scatter of the next); then compounds 2 and 4 (each within the scatter of the next).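

The exchange of 3-cyanophenyl for 3,4-difluorophenyl on a sulfonyl sulfur gives a 1.0-fold higher number from compound 2 to compound 4 (0.01 log units; within the scatter) in this assay, so a halogenated phenyl at this position does not by itself bring the low number of compound 1, 0.18 mL/min. The large step at this position comes instead with one halogen: fluoro in place of chloro on an aromatic carbon gives a 6.3-fold higher number from compound 1 to compound 4 (0.80 log units; beyond the scatter). That exchange does not keep its direction from one core to the other: the same change on two cores in this assay, a 3.3-fold lower number (0.51 log units; beyond the scatter) from compound 2 to compound 3 and a 6.3-fold higher number (0.80 log units; beyond the scatter) from compound 1 to compound 4, 20-fold (1.31 log units) apart, beyond the scatter of two such steps.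

From the compounds shown here alone, it remains open whether the low number of compound 1 needs the chloro together with the fluoro on the sulfonyl aryl, or the chloro alone. Going by these compounds, it also remains open whether a sulfonyl aryl carrying a methoxy or an amine would fall with compound 1 or with compounds 2 and 4.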